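The source may hold more compounds than are shown below. What is called first, only, known or untested is meant among the compounds shown, and "the series" means these compounds.

Measured compounds:
compound 1 `C/C(=N\CCO)c1c(O)c2ccccc2oc1=O` — 92000 nM
compound 2 `C/C(=N\Nc1ccccc1)c1c(O)c2ccccc2oc1=O` — 27000 nM

Going by the values given here, in an assay on isolated protein for inhibition of myosin-2 (Bos taurus), read by spectrophotometry, with a stated time of 24 min (on this read-out higher numbers stand for weaker inhibition and lower numbers for stronger inhibition), compound 1 gives 92000 nM, the highest of the two numbers so far; its nearest neighbour is compound 2 with 27000 nM. Among the compounds with values here, the one step measured, a 3.4-fold lower number from compound 1 to compound 2 (0.53 log units; beyond the scatter), is modest but beyond the scatter and puts anilino in place of 2-hydroxyethyl on a double-bonded nitrogen.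

Compound 3 `C/C(=N\Cc1ccccc1C)c1c(O)c2ccccc2oc1=O` has not yet been measured in this assay. It differs from compound 1 in that (2-methylphenyl in place of hydroxymethyl on a saturated chain carbon bound to a double-bonded nitrogen). Within the data shown here, the only step that bears on this change is the one from compound 1 to compound 2, in which an aromatic ring entered and a hydroxyl-bearing chain left, with a modest lowering of the number. The change to compound 3 also removes a hydroxyl and brings in an aromatic ring, though the place differs, being a saturated chain carbon bound to the double-bonded nitrogen. Among the measured compounds shown here, a step of similar, modest size toward a lower number is therefore expected in this assay, with wide uncertainty since only one step supports it. Compound 3 is expected to give 35000 nM, range 12000 nM to 100000 nM, which means an expected 2.6-fold lower number from compound 1 to compound 3 (0.42 log units; beyond the scatter).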

Compound 3, half-maximal inhibitory concentration: >= 100000 nM
Compound 3: no number, only a limit (the forecaster's own chance of this, stated with the estimate: 10%); at least 2.8-fold (0.45 log units) between middle value and limit.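

Compound 3 gives no number in this assay, only a limit of the assay: the limit of >= 100000 nM in this assay, at which 1 of the 3 values shown sits.

The step reads as an at least 1.0-fold higher number from compound 1 to compound 3 (0.03 log units; that floor lies within the scatter), so this floor does not separate compound 3 from compound 1, and 2-methylphenyl in place of hydroxymethyl on a saturated chain carbon bound to a double-bonded nitrogen shows no lowering of the number. Going by these compounds alone, the earlier step, a 3.4-fold lower number from compound 1 to compound 2 (0.53 log units; beyond the scatter), had left open whether losing the hydroxyl and bringing in an aromatic ring would go with a lower number in general, and compound 3 now goes against that pattern, with compound 2 the only compound of the two that follows it.

From the compounds shown here alone, how far the true value of compound 3 lies beyond its limit remains open, and with it whether this change raises the number at all or leaves it within the scatter. Also open, going by these compounds, is what other groups do at this place on the chain, such as a plain phenyl without the methyl, an amine, a carboxylic acid or a longer chain ending in hydroxyl.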